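Moving the nitro group: what compound 4 might show

The compounds below may be only part of what the source reports. "The series", "measured", "known", "first", "only" and "open" are said of these compounds alone.

The measured compounds and their numbers:

Compound 1, `COc1cc(C(=O)c2cn(-c3cccc(N)c3)cc2-c2ccccc2[N+](=O)[O-])cc(OC)c1OC`, gives 14 nM in a functional assay on MCF7 cells (Homo sapiens) for cytotoxicity, read by MTT assay, with a stated time of 96 h; on this read-out lower numbers stand for stronger inhibition and higher numbers for weaker inhibition.
Compound 2, `COc1cc(C(=O)c2cn(-c3cccc(N)c3)cc2-c2cccc([N+](=O)[O-])c2)cc(OC)c1OC`, gives 510 nM in this assay.
Compound 3, `COc1cc(C(=O)c2cn(-c3ccc(F)cc3)cc2-c2ccccc2[N+](=O)[O-])cc(OC)c1OC`, gives 38 nM in this assay.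

Compound 1 and compound 2 share a core and differ in one group:

3-nitrophenyl in place of 2-nitrophenyl on an aromatic carbon

That change made the number move: a 36-fold higher number from compound 1 to compound 2 (1.56 log units; beyond the scatter).

Compound 3 carries a different group on the ring nitrogen of the core than compound 1 does:

4-fluorophenyl in place of 3-aminophenyl on an aromatic nitrogen

The step that goes with this change is a 2.7-fold higher number from compound 1 to compound 3 (0.43 log units; beyond the scatter).

Compound 4, `COc1cc(C(=O)c2cn(-c3ccc(F)cc3)cc2-c2cccc([N+](=O)[O-])c2)cc(OC)c1OC`, has not been measured. It stands to compound 3 as compound 2 stands to compound 1:

3-nitrophenyl in place of 2-nitrophenyl on an aromatic carbon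

The surroundings of the change are not identical in the two pairs: in compound 1 the ring atom two bonds away bears a 3-aminophenyl group, in compound 3 it bears a 4-fluorophenyl group. The change from compound 3 to compound 4 is therefore the same kind of change, not the same change. Among the measured compounds shown here, with only one earlier example, the expectation rests on that example alone: because a 36-fold higher number from compound 1 to compound 2 (1.56 log units; beyond the scatter) was large, the step from compound 3 to compound 4 is expected to be of a similar size, about a 34-fold higher number from compound 3 to compound 4 (1.53 log units; beyond the scatter). Compound 4 is accordingly estimated at 1300 nM, with a plausible span from 400 nM to 4000 nM.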

Compound 4, half-maximal inhibitory concentration: 440 nM
Compound 4: the middle estimate sits 3.0-fold (0.47 log units) above what was measured; the measured number falls inside the stated range.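

In this assay, 3-nitrophenyl in place of 2-nitrophenyl again gives a large step in the same direction on the core bearing the 4-fluorophenyl group, a 12-fold higher number from compound 3 to compound 4 (1.06 log units; beyond the scatter), but the size of the step does not carry over unchanged: the same change on two cores in this assay, a 36-fold higher number (1.56 log units; beyond the scatter) from compound 1 to compound 2 and a 12-fold higher number (1.06 log units; beyond the scatter) from compound 3 to compound 4, 3.1-fold (0.50 log units) apart, beyond the scatter of two such steps

The other change, 4-fluorophenyl in place of 3-aminophenyl on the ring nitrogen, carries over less well, since its effect seen with the 2-nitrophenyl group does not reappear with the 3-nitrophenyl group, a 1.2-fold lower number from compound 2 to compound 4 (0.06 log units; within the scatter): the same change on two cores in this assay, a 2.7-fold higher number (0.43 log units; beyond the scatter) from compound 1 to compound 3 and a 1.2-fold lower number (0.06 log units; within the scatter) from compound 2 to compound 4, 3.1-fold (0.50 log units) apart, beyond the scatter of two such steps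

So the direction of the nitro move held on both cores, and neither change had one fixed size, but a single pair of cores cannot tell why the sizes differ or predict the step with any other group on the ring nitrogen.

The compounds shown leave open what an amine or a nitrile in place of the nitro group would do on this phenyl ring. They also leave open whether the nitro move would give a large step again with a plain phenyl or a methyl group on the ring nitrogen.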